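The source may report more compounds than this note shows. Statements on the series, on what has been measured and on what is new or still open speak of the compounds shown alone.

In a functional assay on CWR22R cells (Homo sapiens) for antiproliferative activity, read by propidium iodide staining, with a stated time of 96 h (on this read-out higher numbers stand for weaker inhibition and lower numbers for stronger inhibition), compound 1 (`CC(O)(CSc1ccccc1C(F)(F)F)C(=O)Nc1ccc(S(F)(F)(F)(F)F)cc1`) gives 13200 nM and compound 2 (`CC(O)(CSc1ccc(F)cc1)C(=O)Nc1cccc(S(F)(F)(F)(F)F)c1`) gives 30200 nM as its reading. Compound 3 (`CC(O)(COc1cccc(S(F)(F)(F)(F)F)c1)C(=O)Nc1ccc(C#N)cc1C(F)(F)F`) reads 11600 nM which is level with compound 1 within the scatter and lower than compound 2 by a margin beyond the scatter. Compound 4 (`CC(O)(COc1cccc(S(F)(F)(F)(F)F)c1)C(=O)Nc1ccc([N+](=O)[O-])cc1C(F)(F)F`) has nitro in place of cyano on an aromatic carbon and is otherwise the same as compound 3. For the measured compounds named here, no two measured compounds differ in one place only, so nothing yet shows directly what this swap does. No change beyond the scatter is expected, and the estimated 1.2-fold lower number from compound 3 to compound 4 (0.06 log units; within the scatter) stays small. Compound 4 is expected at 10000 nM with an estimated range from 4000 nM to 25000 nM once measured.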

Compound 4, half-maximal inhibitory concentration: 15500 nM
Beside the measured number, compound 4's estimate is 1.6-fold (0.19 log units) below it, within the range that was stated.
By their numbers in this assay, from the lowest: compounds 3, 1, 4 and 2 (each within the scatter of the next, the first and the last beyond it).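

In this assay nitro in place of cyano, on an aromatic carbon para to a large group and meta to a trifluoromethyl group, gives a 1.3-fold higher number from compound 3 to compound 4 (0.13 log units; within the scatter) as its step. For the compounds shown here, this is the first direct comparison at this position, and it shows that the two groups cannot be told apart here. Nothing available explains why these two groups read alike.

Going by these compounds, whether an amine or a carboxylic acid at this position would give a different number remains open. So does whether this swap would give the same result on another core.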